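Butoxy in Place of an Ester Ether on the Benzyl Arm

A few compounds are considered here, and "the series" means these few. Any claim that something is new, unique, unknown or untested is made for them only; others in the source may bear on it.

Of the compounds shown here, three built on a shared core have been tested in a toxicity assay on MDCK cells (Canis lupus familiaris) for cytotoxicity, read by crystal violet staining, with a stated time of 48 h; on this read-out higher numbers stand for lower toxicity in this test and lower numbers for higher toxicity in this test. Compound 1 `CCCc1ccc2[nH]c(=O)c(CN(Cc3ccc(F)cc3)Cc3ccc(C(C)(C)C)cc3)cc2c1` gives 8400 nM. Compound 2 `Cc1ccc2cc(CNCc3ccc(F)cc3)c(=O)[nH]c2c1` reaches only a limit of the assay, > 33000 nM, and not a number. Compound 3 `Cc1ccc2[nH]c(=O)c(CN(Cc3ccc(OCC(=O)OC(C)(C)C)cc3)Cc3ccc(C(C)(C)C)cc3)cc2c1` likewise returns only a limit, > 10000 nM. Compound 3 thus stands at the limit of > 10000 nM in this assay, at which 1 of the 3 values shown sits. The remaining limit, (the limit of > 33000 nM in this assay, at which 1 of the 3 values shown sits), belongs to compound 2. For the measured compounds named here, with two of the three values given only as limits, compound 3 cannot be ranked against compound 2, and compound 1 is the single compound with a measured number.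

Compound 4 `CCCCOc1ccc(CN(Cc2ccc(C(C)(C)C)cc2)Cc2cc3cc(C)ccc3[nH]c2=O)cc1` has not yet been measured in this assay. It differs from compound 3 in one place: propyl in place of tert-butoxycarbonyl on a saturated chain carbon bound to an oxygen on an aromatic ring. Going by the values given here, no pair of measured compounds repeats this change, so no measured step sets its size. Because compound 3 itself sits at the limit of > 10000 nM in this assay, at which 1 of the 3 values shown sits, only a departure from that limit could be judged, and the change touches a side chain on the benzyl arm rather than the core. Compound 4 is therefore expected to remain near compound 3, and the step that this estimate means is expected to be a step that the limit leaves unreadable from compound 3 to compound 4, within the usual scatter. Compound 4 is estimated at 12000 nM, with a range from 4000 nM to 35000 nM.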

Compound 4, half-maximal cytotoxic concentration: > 5000 nM
Compound 4: only a limit was reported; the forecaster's own chance of this, stated with the estimate: 55%; the middle value does not contradict the limit.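

In this assay compound 4 gives only a limit, > 5000 nM. For the compounds shown here, compound 3 likewise gives only a limit, > 10000 nM, so no step from compound 3 to compound 4 can be read. The compounds shown leave open whether butoxy in place of (tert-butoxycarbonyl)methoxy changes the half-maximal cytotoxic concentration at all, and in which direction.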